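One Added Chloro on the Weaker Compound

The compounds below may be only part of what the source reports. "The series", "measured", "known", "first", "only" and "open" are said of these compounds alone.

In a functional assay on UACC-62 cells (Homo sapiens) for inhibition, read by sulforhodamine B assay, with a stated time of 48 h (on this read-out lower numbers stand for stronger inhibition of growth and higher numbers for weaker inhibition of growth), compound 1 `COc1cc(-c2nn(-c3cccc(NC(=O)Nc4cc(C(F)(F)F)cc(C(F)(F)F)c4)c3)cc2-c2ccncc2)ccc1Cl` gives 661 nM and compound 2 `COc1cc(-c2nn(-c3cccc(NC(=O)c4cccc(C(F)(F)F)c4)c3)cc2-c2ccncc2)ccc1Cl` gives 1940 nM as the higher of the two numbers, a gap beyond the usual scatter. Compound 3 `COc1cc(-c2nn(-c3cccc(NC(=O)c4ccc(Cl)c(C(F)(F)F)c4)c3)cc2-c2ccncc2)ccc1Cl` differs from compound 2 in one place chloro in place of hydrogen on an aromatic carbon with chloro in place of hydrogen on an aromatic carbon, turning 3-(trifluoromethyl)phenyl into 4-chloro-3-(trifluoromethyl)phenyl. Going by the values given here, no measured pair shows this change, so the expectation is only tentative. A modest gain in inhibition is expected in this assay as a 1.8-fold lower number from compound 2 to compound 3 (0.25 log units; within the scatter) in the estimate. For compound 3 the estimated value is 1100 nM with a likely range from 450 nM to 2600 nM around it.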

Compound 3, concentration for 50% growth inhibition: 2100 nM
For compound 3 the middle estimate is 1.9-fold (0.28 log units) below the measured one, and the stated range covers the measured number.
By their numbers in this assay, from the lowest: compound 1; then compounds 2 and 3 (each within the scatter of the next).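

In this assay the chloro added on this aromatic carbon, ortho to a trifluoromethyl group, gives a 1.1-fold higher number from compound 2 to compound 3 (0.03 log units; within the scatter) and so leaves growth inhibition indistinguishable from that of compound 2. This single change therefore offers no gain at this position, a point the comparison of compound 1 with compound 2 could not show because they differ in more than one place. No measurement available here explains this outcome. Going by these compounds, whether a fluoro atom or an amine on this same carbon would give a different number remains open.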